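Replacing a Fluorine with a Carboxylic Acid on the Benzothiazole

The source may report more compounds than this note shows. Statements on the series, on what has been measured and on what is new or still open speak of the compounds shown alone.

Compound 1 `O=c1cc(-c2ccccc2)oc2cc(OCCCCNc3nc4ccc(Br)cc4s3)cc(O)c12` and compound 2 `O=c1cc(-c2ccccc2)oc2cc(OCCCCNc3nc4ccc(F)cc4s3)cc(O)c12` share one core and differ only in a halogen. In a functional assay on Ca-Ski cells (Homo sapiens) for cytotoxicity, read by sulforhodamine B assay, with a stated time of 48 h (on this read-out higher numbers stand for weaker inhibition and lower numbers for stronger inhibition), compound 1 gives 12.4 ug/mL, and compound 2 gives 13.4 ug/mL. Compound 2 holds the higher of the two numbers, but the step of a 1.1-fold higher number from compound 1 to compound 2 (0.03 log units; within the scatter) shows the two cannot be told apart. Compound 3 `O=C(O)c1ccc2nc(NCCCCOc3cc(O)c4c(=O)cc(-c5ccccc5)oc4c3)sc2c1` is not yet measured; it carries the change (carboxy in place of fluoro on an aromatic carbon). For the measured compounds named here, the only measured step swaps one halogen for another, and it was within the scatter; no measured step exchanges a halogen for a carboxy group, so there is no direct guide. With nothing to point either way, the expected step of a 1.1-fold higher number from compound 2 to compound 3 (0.05 log units; within the scatter) in this assay is none beyond the scatter. Compound 3 is therefore estimated at 15 ug/mL, with a likely range from 6 ug/mL to 40 ug/mL.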

Compound 3, half-maximal inhibitory concentration: 12.1 ug/mL
Compound 3: the middle estimate sits 1.2-fold (0.09 log units) above what was measured; the measured number falls inside the stated range.
By their numbers in this assay, from the lowest: compounds 3, 1 and 2 (each within the scatter of the next).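

In this assay, the swap of fluoro for carboxy gives a 1.1-fold lower number from compound 2 to compound 3 (0.04 log units; within the scatter) and the swap of bromo for carboxy gives a 1.0-fold lower number from compound 1 to compound 3 (0.01 log units; within the scatter) on the same core. The earlier compounds shown here compared only two halogens, whereas this position now also holds a group of three heavy atoms with a hydrogen-bond donor and acceptor, and the three numbers still cannot be told apart. Nothing available here explains why the three compounds read alike.

As far as these compounds go, whether any group at this position moves the number beyond the scatter stays open, for example an amine or a methyl ester. Also open, from the compounds shown here alone, is whether a longer chain would change the reading, and whether these compounds would read alike in other cell lines.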